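Aryl urea variation on a chloropyrazinylmethyl aniline core

This account rests on a few compounds, and the source may have more. Where it says the series, first, only, none or still open, it means among the compounds named here.

Of the compounds shown here, three sharing one core have been tested in a functional assay on T-24 cells (Homo sapiens) for antiproliferative activity, read by MTT assay, with a stated time of 48 h; a higher number here means a weaker inhibitor, a lower number a stronger inhibitor. Compound 1 `O=C(Nc1cccc(CNc2nccnc2Cl)c1)Nc1ccccc1Cl` gives 6680 nM in this assay, compound 2 `O=C(Nc1cccc(CNc2nccnc2Cl)c1)Nc1ccc(Cl)cc1Br` gives 6650 nM, and compound 3 `Cc1ccc(NC(=O)Nc2cccc(CNc3nccnc3Cl)c2)c(C)c1` gives 9230 nM. Compound 1 stands second highest of the three numbers, but every step among them is within the scatter: a 1.0-fold lower number from compound 1 to compound 2 (0.00 log units; within the scatter), a 1.4-fold higher number from compound 1 to compound 3 (0.14 log units; within the scatter), and a 1.4-fold higher number from compound 2 to compound 3 (0.14 log units; within the scatter). The aryl group on the amide-type nitrogen has thus been varied three ways without any step beyond the scatter.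

Compound 4 `COc1ccc(NC(=O)Nc2cccc(CNc3nccnc3Cl)c2)cc1` is not yet measured in this assay. It differs from compound 1 as follows: 4-methoxyphenyl in place of 2-chlorophenyl on an amide-type nitrogen. The measured steps bear on it only in that each exchange of this aryl group has so far stayed within the scatter, and none of them places a methoxy group on the ring. The expectation for compound 4 is therefore a number near that of compound 1, a 1.2-fold higher number from compound 1 to compound 4 (0.08 log units; within the scatter), within the scatter. Compound 4 is estimated at 8000 nM, expected to lie between 3500 nM and 20000 nM.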

Compound 4, half-maximal inhibitory concentration: 9820 nM
Beside the measured number, compound 4's estimate is 1.2-fold (0.09 log units) below it; the range from low to high includes it.
By their numbers in this assay, from the lowest: compounds 2, 1, 3 and 4 (each within the scatter of the next).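

Unlike the three earlier aryl groups, 4-methoxyphenyl brings an oxygen and a hydrogen-bond acceptor to this amide-type nitrogen, yet in this assay all three new steps stay within the scatter (a 1.5-fold higher number from compound 1 to compound 4 (0.17 log units; within the scatter); a 1.5-fold higher number from compound 2 to compound 4 (0.17 log units; within the scatter); a 1.1-fold higher number from compound 3 to compound 4 (0.03 log units; within the scatter)). The flat picture among compounds 1, 2 and 3 therefore also holds for compound 4, whose ring carries a methoxy group and neither a halogen nor a methyl group. Nothing available explains why these numbers stay so close.

From the compounds shown here alone, all four compounds keep an aryl group at this place and share the same core, so it remains open whether any change here can produce a step beyond the scatter. A ring bearing an amine or a carboxylic acid, or a longer alkyl chain in place of the aryl group, would test this.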